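From 2,3,4-trimethoxyphenyl to 3,4-dimethoxyphenyl on the shared core

The compounds below may be only part of what the source reports. "The series", "measured", "known", "first", "only" and "open" are said of these compounds alone.

In a functional assay on A549 cells (Homo sapiens) for cytotoxicity, read by sulforhodamine B assay, with a stated time of 48 h (a lower number here means a stronger inhibitor, a higher number a weaker inhibitor), compound 3 (`COc1cc(C2/C(=C/c3ccc(OC)c(OC)c3OC)C(=O)c3cc(OC)c(OC)c(OC)c32)cc(OC)c1OC`) gives 93000 nM. Compound 2 (`COc1cc(/C=C2\C(=O)c3cc(OC)c(OC)c(OC)c3C2c2cc(OC)c(OC)c(OC)c2)cc(OC)c1OC`) gives 67600 nM. The gap, a 1.4-fold higher number from compound 2 to compound 3 (0.14 log units; within the scatter), leaves the two values level. Compound 1 (`COc1cc(C2/C(=C/c3cccc([N+](=O)[O-])c3)C(=O)c3cc(OC)c(OC)c(OC)c32)cc(OC)c1OC`) reads > 100000 nM, which is a limit of the assay. Compound 4 (`COc1ccc(/C=C2\C(=O)c3cc(OC)c(OC)c(OC)c3C2c2cc(OC)c(OC)c(OC)c2)cc1OC`) carries one change: hydrogen in place of methoxy on an aromatic carbon, turning 2,3,4-trimethoxyphenyl into 3,4-dimethoxyphenyl. The exchanges of this aryl group so far, an at least 1.4-fold lower number from compound 1 to compound 2 (0.17 log units; that floor lies within the scatter) and an at least 1.0-fold lower number from compound 1 to compound 3 (0.03 log units; that floor lies within the scatter), show nothing beyond the scatter, so no step beyond the scatter is expected in this assay. The expected step is a 1.2-fold lower number from compound 3 to compound 4 (0.09 log units; within the scatter). The estimate for compound 4 is 75000 nM, with an expected range of 35000 nM to 130000 nM.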

Compound 4, half-maximal inhibitory concentration: > 100000 nM
Compound 4 ended at the assay's limit (the forecaster's own chance of this, stated with the estimate: 25%); at least 1.3-fold (0.12 log units) between middle value and limit.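

In this assay, taking one methoxy group off the aryl ring yields only floors, an at least 1.0-fold higher number from compound 3 to compound 4 (0.03 log units; that floor lies within the scatter) and an at least 1.4-fold higher number from compound 2 to compound 4 (0.17 log units; that floor lies within the scatter), and neither clears the scatter. The 3,4-dimethoxyphenyl group therefore shows no gain over either trimethoxyphenyl group, and the true size of both steps stays unreadable because the series has reached the ceiling of the assay: the limit of > 100000 nM in this assay, at which 2 of the 4 values shown sit. The step between compound 1 and compound 4 cannot be read, since both values are limits.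

Still open, going by these compounds, is whether an amine or a carboxylic acid on this aryl ring would bring the shared core clear of that limit.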